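A few compounds are considered here, and "the series" means these few. Any claim that something is new, unique, unknown or untested is made for them only; others in the source may bear on it.

Going by the values given here, compound 1 `CCOC(=O)[C@@]1(C(=O)Nc2ccccc2Cl)C[C@H]1c1cc(OC)c(OC)c(OC)c1` gives 17600 nM in a functional assay on A549 cells (Homo sapiens) for cytotoxicity, read by MTT assay, with a stated time of 48 h (a higher number here means a weaker inhibitor, a lower number a stronger inhibitor), the higher of the two numbers measured so far. Its closest neighbour is compound 2 `CCOC(=O)[C@]1(C(=O)Nc2ccccc2Cl)C[C@H]1c1cc(OC)c(OC)c(OC)c1`, which gives 13400 nM in this assay; the step of a 1.3-fold lower number from compound 1 to compound 2 (0.12 log units; within the scatter) is one of configuration only, because of the fact that compounds 1 and 2 differ only in the configuration as drawn. Compound 3 `CCOC(=O)[C@@]1(C(=O)Nc2ccccc2)C[C@H]1c1cc(OC)c(OC)c(OC)c1` is the unmeasured partner, differing from compound 1 by hydrogen in place of chloro on an aromatic carbon. Among the compounds with values here, no measured step touches that change; the only step seen stayed within the scatter, so nothing here points to a large shift. The estimated step of a 1.1-fold higher number from compound 1 to compound 3 (0.06 log units; within the scatter) is therefore small. Compound 3 is expected to give 20000 nM, between 8000 nM and 50000 nM.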

Compound 3, half-maximal inhibitory concentration: 65900 nM
Compound 3: middle estimate off by 3.3-fold (0.52 log units), on the low side; the whole stated range lies below it.
By their numbers in this assay, from the lowest: compounds 2 and 1 (each within the scatter of the next); then compound 3.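

Going by these compounds alone, on the 2-chlorophenyl group, replacing chloro with hydrogen on the aromatic carbon ortho to a large group produces in this assay a 3.7-fold higher number from compound 1 to compound 3 (0.57 log units; beyond the scatter) and so gives the first change in this set that moves the number beyond the scatter. Compound 1, with the chloro, is therefore the stronger inhibitor of this pair, and this position responds to a change of a single atom. Nothing available explains why the number moves. As far as these compounds go, whether a bromo or methyl group at this position would match chloro stays open, as does whether removing chloro from compound 2 has the same effect.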